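From a hydroxyalkyl to a methylsulfanyl side group

This account rests on a few compounds, and the source may have more. Where it says the series, first, only, none or still open, it means among the compounds named here.

Compound 1 `COCCOCC1CN(c2ccccc2)NC1=O`: 520 nM
Compound 2 `COCCC1CN(c2ccccc2)NC1=O`: 480 nM; 10300 nM; 350 nM (3 entries)
Compound 3 `CC(C)(O)C1CN(c2ccccc2)NC1=O`: > 1000 nM

In an assay on isolated protein for inhibition of Polyunsaturated fatty acid 5-lipoxygenase (Rattus norvegicus) (a lower number here means a stronger inhibitor, a higher number a weaker inhibitor), compound 1 gives 520 nM. Compound 2 gives 480 nM; 10300 nM; 350 nM (3 entries) in this assay, and the several entries of compound 2 in this assay, 480 nM; 10300 nM; 350 nM (3 entries) show how widely repeated entries of one compound can spread. For compound 3 this assay reports only a limit, > 1000 nM, and no number. Going by the values given here, the one step that is measured, an at least 1.9-fold higher number from compound 1 to compound 3 (0.28 log units; that floor lies within the scatter), therefore has only a floor, because the limit of > 1000 nM in this assay, at which 1 of the 3 values shown sits, leaves the upper side open.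

Compound 4 `CSC1CN(c2ccccc2)NC1=O` differs from compound 3 by methylsulfanyl in place of 1-hydroxy-1-methylethyl on a saturated ring carbon. The step from compound 1 to compound 3 shows that a group with a hydroxyl on this saturated ring carbon goes with the weakest number shown, while the two ether-bearing compounds 1 and 2 sit close to each other. Compound 4 carries no hydrogen-bond donor in the new group, so it is expected to move back toward the values of compounds 1 and 2, an expected step of an at least 1.4-fold lower number from compound 3 to compound 4 (0.15 log units; that floor lies within the scatter). Compound 4 is estimated at 700 nM, within 200 nM to 3000 nM.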

Compound 4, half-maximal inhibitory concentration: 320 nM
Compound 4: middle estimate off by 2.2-fold (0.34 log units), on the high side; low and high end bracket the measured number.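

In this assay, going by these compounds alone, the change to methylsulfanyl on this saturated ring carbon gives the first step at this position that lies beyond the scatter, an at least 3.1-fold lower number from compound 3 to compound 4 (0.49 log units; beyond the scatter). That step is only a floor, with its size open on one side, since compound 3 has a limit and no number: the limit of > 1000 nM in this assay, at which 1 of the 4 values shown sits. Against the (2-methoxyethoxy)methyl group the same change gives a 1.6-fold lower number from compound 1 to compound 4 (0.21 log units; within the scatter), so methylsulfanyl, with 2 heavy atoms, holds the level of that far larger ether chain within the scatter.

The step from compound 3 to compound 4 swaps the hydroxyl, the branched carbons and the sulfur all at once, and the compounds shown do not separate these parts. A methoxy group, an ethyl group or an amine on this ring carbon would speak to that question.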